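This account rests on a few compounds, and the source may have more. Where it says the series, first, only, none or still open, it means among the compounds named here.

Measured compounds in a functional assay on MDA-MB-231 cells (Homo sapiens) for cytotoxicity, read by MTT assay, with a stated time of 48 h; on this read-out lower numbers stand for stronger inhibition and higher numbers for weaker inhibition:
compound 1 `O=C(NCCCCC(c1ccc(F)cc1)c1ccc(F)cc1)Nc1ccc(Cl)cc1` gives 7680 nM.
compound 2 `Nc1ccc(NC(=O)NCCCCC(c2ccc(F)cc2)c2ccc(F)cc2)cc1` returns only a limit, > 20000 nM.
compound 3 `CC(=O)Nc1ccc(NC(=O)NCCCCC(c2ccc(F)cc2)c2ccc(F)cc2)cc1` also returns only a limit, > 20000 nM.

Compound 3 therefore stands at the limit of > 20000 nM in this assay, at which 2 of the 3 values shown sit, with no number of its own in this assay. The change to compound 4 `Cc1cc(Cl)ccc1NC(=O)NCCCCC(c1ccc(F)cc1)c1ccc(F)cc1` is 4-chloro-2-methylphenyl in place of 4-acetamidophenyl on an amide-type nitrogen. For the measured compounds named here, the steps that bear on it are an at least 2.6-fold higher number from compound 1 to compound 3 (0.41 log units; beyond the scatter) and an at least 2.6-fold higher number from compound 1 to compound 2 (0.41 log units; beyond the scatter); compound 4 largely undoes the first, since its 4-chloro-2-methylphenyl differs from the 4-chlorophenyl of compound 1 by a methyl. A return toward the number of compound 1 is expected; the expected step is an at least 3.3-fold lower number from compound 3 to compound 4 (0.52 log units; beyond the scatter). For compound 4 the estimate is 6000 nM, with a range from 2500 nM to 15000 nM.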

Compound 4, half-maximal inhibitory concentration: > 20000 nM
Compound 4: only a limit was reported; the forecaster's own chance of this, stated with the estimate: 15%; middle value at least 3.3-fold (0.52 log units) away from the limit.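

In this assay, a methyl in place of hydrogen on an aromatic carbon gives an at least 2.6-fold higher number from compound 1 to compound 4 (0.41 log units; beyond the scatter), so keeping the chloro group on the ring does not by itself preserve a measurable number. The steps to compound 4 from compound 2 and from compound 3 cannot be read, as both ends of each are limits. Compound 4 returns only a limit, leaving compound 1 the sole compound here with a number: the limit of > 20000 nM in this assay, at which 3 of the 4 values shown sit.

From the compounds shown here alone, it remains open how far compound 4 lies past its limit. Also open, going by these compounds, is whether a fluoro or a methoxy in place of this methyl would keep a measurable number.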